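An Ester in Place of the Thiazole: Compound 4 Foreseen

The source may report more compounds than this note shows. Statements on the series, on what has been measured and on what is new or still open speak of the compounds shown alone.

Three measured compounds share one core. Compound 1 `COC(=O)/C=C/c1cccc(N(Cc2ccc(/C=C/c3scnc3C)cc2)C(=O)C2CCCCC2)c1` gives 227 nM in an assay on isolated protein with Bile acid receptor (Homo sapiens) as the target; a higher number here means that more compound is needed for the effect, a lower number that less compound is needed; it is the second highest of the three numbers, its nearest neighbour being compound 2 `COC(=O)/C=C/c1cccc(N(Cc2ccc(/C=C/c3scnc3C)cc2)C(=O)C(C)C)c1` with 228 nM and its furthest compound 3 `COC(=O)/C=C/c1cccc(N(Cc2ccc(/C=C/C(=O)OC(C)(C)C)cc2)C(=O)NC(C)C)c1` with 212 nM, both gaps lying within the scatter. Among the measured compounds shown here, the one single-point step available, a 1.0-fold higher number from compound 1 to compound 2 (0.00 log units; within the scatter), shows that exchanging the group on the carbonyl carbon left the number unchanged.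

Compound 4 `CCOC(=O)/C=C/c1ccc(CN(C(=O)C2CCCCC2)c2cccc(/C=C/C(=O)OC)c2)cc1` differs from compound 1 at the far end of the molecule: ethoxycarbonyl in place of 4-methyl-1,3-thiazol-5-yl on a double-bonded chain carbon bound to a double-bonded chain carbon. For the measured compounds named here, no measured pair isolates this exchange. Compound 3, which also carries an ester on that ethenyl arm though with a different acyl group, sits within the scatter of compound 1, so the series gives no sign that the thiazole is needed for the effect.

Compound 4 is therefore expected to show a 1.0-fold higher number from compound 1 to compound 4 (0.01 log units; within the scatter), no more than the scatter. The estimated value for compound 4 is 230 nM, with a range from 110 nM to 480 nM.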

Compound 4, half-maximal effective concentration: > 1000 nM
Compound 4 ended at the assay's limit (the forecaster's own chance of this, stated with the estimate: 5%); middle value at least 4.3-fold (0.63 log units) away from the limit.
By their numbers in this assay, from the lowest: compounds 3, 1 and 2 (each within the scatter of the next). At a limit, above all of these: compound 4.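

In this assay, putting ethoxycarbonyl in place of 4-methyl-1,3-thiazol-5-yl gives an at least 4.4-fold higher number from compound 1 to compound 4 (0.64 log units; beyond the scatter). Among the compounds shown here, this position, on a double-bonded chain carbon bound to a double-bonded chain carbon, therefore responds to exchange, whereas the only earlier step, a 1.0-fold higher number from compound 1 to compound 2 (0.00 log units; within the scatter), at the group on the carbonyl carbon, left the number unchanged. The value of compound 4 is a limit of the assay and not a number, so this step has a lower bound only: the limit of > 1000 nM in this assay, at which 1 of the 4 values shown sits.

The compounds shown leave open whether the thiazole itself matters or the ethoxycarbonyl group is what counts against the effect, and what a carboxylic acid, a primary amide or a phenyl ring would give on the same ethenyl arm. They also leave open whether the exchange would give a similar step with the isopropyl group of compound 2.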